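Anilino to benzylamino on a nitropyrimidine core

This account rests on a few compounds, and the source may have more. Where it says the series, first, only, none or still open, it means among the compounds named here.

Of the compounds shown here, three sharing one core have been measured in a functional assay on MDA-MB-231 cells (Homo sapiens) for antiproliferative activity, read by MTT assay, with a stated time of 48 h; a lower number here means a stronger inhibitor, a higher number a weaker inhibitor. Compound 1 `CCOC(=O)CNc1nc(Nc2cccc(OC)c2)ncc1[N+](=O)[O-]` gives 31300 nM, and compound 3 `CCOC(=O)CN(Cc1ccccc1)c1nc(Nc2ccc(Cl)cc2)ncc1[N+](=O)[O-]` gives 34400 nM; these two values lie within the usual scatter of each other. Compound 2 `COC(=O)CN(C)c1nc(Nc2ccccc2)ncc1[N+](=O)[O-]` is reported only as a limit of this assay, > 100000 nM, which is the limit of > 100000 nM in this assay, at which 1 of the 3 values shown sits. Compound 4 `COC(=O)CN(C)c1nc(NCc2ccccc2)ncc1[N+](=O)[O-]` has not yet been measured; it differs from compound 2 by benzyl in place of phenyl on a nitrogen on an aromatic ring. For the measured compounds named here, no measured pair shows the size such a change brings, so the step of a number no higher from compound 2 to compound 4 (the limit leaves the size open) is an expectation only, and with compound 2 at a limit that expectation is no clearer than the limit itself. Compound 4 is expected to give about 100000 nM, between 30000 nM and 300000 nM, with a fair chance that only a limit is again reported.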

Compound 4, half-maximal inhibitory concentration: 61100 nM
Compound 4: middle estimate off by 1.6-fold (0.21 log units), on the high side; measured number inside the range.
By their numbers in this assay, from the lowest: compounds 1, 3 and 4 (each within the scatter of the next). At a limit, above all of these: compound 2.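

Benzyl in place of phenyl on a nitrogen on an aromatic ring gives the only single-place comparison in this assay, with an at least 1.6-fold lower number from compound 2 to compound 4 (0.21 log units; that floor lies within the scatter). Going by these compounds, the true size of this step stays unknown, because compound 2 sits at a limit: the limit of > 100000 nM in this assay, at which 1 of the 4 values shown sits. Anilino to benzylamino thus yields a measured number for compound 4, but the floor alone does not establish a real gain. On these data alone, whether a longer chain such as phenethyl on that nitrogen would change the number stays open. So does the effect of a carboxylic acid in place of the methyl ester.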